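A few compounds are considered here, and "the series" means these few. Any claim that something is new, unique, unknown or untested is made for them only; others in the source may bear on it.

Within the data shown here, compound 2 `Cc1ccc(NC2=CC(=O)c3c(nc4n3[C@H]3OC[C@@H](O)[C@H]3OC4)C2=O)cc1C` is the one member with a number in a functional assay on MCF7 cells (Homo sapiens) for inhibition, read by sulforhodamine B assay (a lower number here means a stronger inhibitor, a higher number a weaker inhibitor), where compound 2 gives 4950 nM. Compound 1 `CCCc1ccc(NC2=CC(=O)c3c(nc4n3[C@H]3OC[C@@H](O)[C@H]3OC4)C2=O)cc1` reaches only the limit > 4000 nM in this assay. Compound 3 `COc1cccc(NC2=CC(=O)c3nc4n(c3C2=O)[C@H]2OC[C@@H](O)[C@H]2OC4)c1` likewise reaches only the limit > 4000 nM. Among the measured compounds shown here, the one counted step, a step that the limit leaves unreadable from compound 1 to compound 2, stays of unknown size because the limit of > 4000 nM in this assay, at which 2 of the 3 values shown sit, covers compound 1. Compound 4 `O=C1C(NC2CCCC2)=CC(=O)c2c1nc1n2[C@H]2OC[C@@H](O)[C@H]2OC1` differs from compound 2 by cyclopentyl in place of 3,4-dimethylphenyl on an amine nitrogen. For the measured compounds named here, no measured step replaces 3,4-dimethylphenyl with cyclopentyl on the amine nitrogen, so no direction can be read from the series, which sits throughout at weak inhibition. The expected step is a 1.0-fold higher number from compound 2 to compound 4 (0.00 log units; within the scatter), with no settled direction. The estimate for compound 4 in this assay is 5000 nM, between 1500 nM and 20000 nM.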

Compound 4, half-maximal inhibitory concentration: > 16000 nM
Compound 4: a limit, no number; the forecaster's own chance of this, stated with the estimate: 50%; at least 3.2-fold (0.50 log units) between middle value and limit.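

Among these compounds, on the amine nitrogen, cyclopentyl in place of 3,4-dimethylphenyl gives the first readable change at this position in this assay, an at least 3.2-fold higher number from compound 2 to compound 4 (0.50 log units; beyond the scatter). Compound 4 gives > 16000 nM, which is a limit and not a number. In this one readable pair, the non-aromatic ring gives weaker inhibition than the substituted aromatic ring, while the steps from compound 1 cannot be read.

On these data alone, the full size of the loss stays open. So does whether a benzyl group on the amine nitrogen would read closer to compound 2 or compound 4.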